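A few compounds are considered here, and "the series" means these few. Any claim that something is new, unique, unknown or untested is made for them only; others in the source may bear on it.

Compound 1 `COc1ccc(C2=C(c3cc(OC)c(OC)c(OC)c3)C(=O)C(O[SiH2]C(C)(C)C)C2)cc1OC(C)C` was examined in an ADME assay on HEK293 cells (Homo sapiens) for cytotoxicity, read by MTT assay, with a stated time of 72 h; on this read-out lower numbers stand for stronger inhibition and higher numbers for weaker inhibition. For compound 1 this assay reports only a limit, > 100 ug/mL. Among the compounds with values here, the two other compounds tested so far sit at the same point. Compound 2 `COc1ccc(C2=C(c3cc(OC)c(OC)c(OC)c3)CC(O)C2=O)cc1[N+](=O)[O-]` gives a limit of > 100 ug/mL in this assay. Compound 3 `COC(=O)c1cc(C2=C(c3cc(OC)c(OC)c(OC)c3)C(=O)CC2O[SiH2]C(C)(C)C)ccc1OC` likewise gives a limit of > 100 ug/mL. Within the data shown here, the picture so far is therefore (the limit of > 100 ug/mL in this assay, at which 3 of the 3 values shown sit), and no step between measured compounds can be drawn; compound 1 stands nowhere in particular among numbers, since it shares a limit with every other compound tested.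

Compound 4 `COc1ccc(C2=C(c3cc(OC)c(OC)c(OC)c3)C(=O)C(OC(C)=O)C2)cc1OC(C)C` has not yet been measured. It differs from compound 1 by a group of 3 heavy atoms (2 carbon, 1 oxygen; no ring) in place of a group of 5 heavy atoms (4 carbon, 1 silicon; no ring), on an oxygen on a saturated carbon. The acetyl enters on an oxygen on a saturated carbon whose other neighbour is a saturated ring carbon, where the group of 5 heavy atoms leaves.

Among the measured compounds shown here, with no measured step to lean on, the expected step in this assay is a step that the limit leaves unreadable from compound 1 to compound 4, none beyond the scatter. Compound 4 is accordingly estimated at 150 ug/mL, in a range from 60 ug/mL to 400 ug/mL.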

Compound 4, half-maximal inhibitory concentration: > 100 ug/mL
Compound 4: only a limit was reported; the forecaster's own chance of this, stated with the estimate: 80%; the middle value does not contradict the limit.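

In this assay, within the data shown here, compound 4 gives only a limit, > 100 ug/mL, so no step from compound 1 to compound 4 can be read. The compounds shown leave open how any of them ranks on this read-out, as all share one limit: the limit of > 100 ug/mL in this assay, at which 4 of the 4 values shown sit.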